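Notes on one untested analogue in a small series

This account rests on a few compounds, and the source may have more. Where it says the series, first, only, none or still open, it means among the compounds named here.

Measured so far:
compound 1 `Oc1ccc(-c2cc(-c3ccccc3F)cc(-c3cccc(O)c3)n2)cc1` gives 6370 nM in a functional assay on T47D cells (Homo sapiens) for inhibition; on this read-out lower numbers stand for stronger inhibition and higher numbers for weaker inhibition
compound 2 `Oc1ccc(-c2cc(-c3ccccc3C(F)(F)F)cc(-c3cccc(O)c3)n2)cc1` gives 3210 nM in this assay
compound 3 `Oc1ccc(-c2cc(-c3cccc(C(F)(F)F)c3)cc(-c3cccc(O)c3)n2)cc1` gives 2630 nM in this assay

Compound 3 stands at the low end of the three numbers in this assay. Against compound 2 the difference is small, a 1.2-fold lower number from compound 2 to compound 3 (0.09 log units; within the scatter), so the two cannot be ordered. Against compound 1 the difference is a 2.4-fold lower number from compound 1 to compound 3 (0.38 log units; beyond the scatter), a modest step that stands beyond the scatter. The step from fluoro to trifluoromethyl on the same carbon, a 2.0-fold lower number from compound 1 to compound 2 (0.30 log units; within the scatter), stays within the scatter.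

Compound 4 `Oc1ccc(-c2cc(-c3cccc(OC(F)(F)F)c3)cc(-c3cccc(O)c3)n2)cc1` differs from compound 3 in one place: trifluoromethoxy in place of trifluoromethyl on an aromatic carbon. Among the compounds with values here, none of the measured steps exchanges trifluoromethyl for trifluoromethoxy; the steps seen so far concern fluoro against trifluoromethyl and the position of the trifluoromethyl on that ring, and all three were small, the largest being a 2.4-fold lower number from compound 1 to compound 3 (0.38 log units; beyond the scatter). There is therefore no basis for expecting a step beyond the scatter in this assay in either direction. The expected step is a 1.0-fold lower number from compound 3 to compound 4 (0.00 log units; within the scatter), an estimate only. For compound 4 the estimated value in this assay is 2600 nM, with a range from 1000 nM to 6500 nM.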

Compound 4, half-maximal inhibitory concentration: 5040 nM
Beside the measured number, compound 4's estimate is 1.9-fold (0.29 log units) below it; measured number inside the range.
By their numbers in this assay, from the lowest: compounds 3, 2, 4 and 1 (each within the scatter of the next, the first and the last beyond it).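

In this assay, trifluoromethoxy in place of trifluoromethyl, on an aromatic carbon meta to a large group, gives a 1.9-fold higher number from compound 3 to compound 4 (0.28 log units; within the scatter) and so leaves compound 3 and compound 4 unordered on this read-out. Within the data shown here, this is the first exchange that alters the group itself at this position rather than its place on the ring, and the oxygen that enters, with the hydrogen-bond acceptor counted for it, does not carry the number beyond the scatter. No measurement at hand bears on this step.

The compounds shown therefore establish only that these two fluorinated groups cannot be told apart at this position, and they do not settle whether the number at this position can move much at all. From the compounds shown here alone, whether a methoxy group, an amine or a carboxylic acid on the same carbon would give a step beyond the scatter in this assay remains open, as does whether trifluoromethoxy would match trifluoromethyl on the other ring carbon occupied in compound 2.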